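A Triple Bond Swapped for a Double Bond

This account rests on a few compounds, and the source may have more. Where it says the series, first, only, none or still open, it means among the compounds named here.

Compound 1 `C#CC(=O)N(Cc1ccc(OC)c(O)c1)c1cc(OC)c(OC)c(OC)c1` gives 170 nM in a functional assay on MGC-803 cells (Homo sapiens) for inhibition, read by MTT assay, with a stated time of 48 h; a lower number here means a stronger inhibitor, a higher number a weaker inhibitor. Among the numbers measured so far, compound 1 stands lowest; the nearest measured number belongs to compound 2, and the gap between them is well beyond the usual scatter. Compound 2 `COC(=O)c1cc(CNc2cc(OC)c(OC)c(OC)c2)ccc1OC` gives 49600 nM in this assay. Compound 3 `COc1cc(NCc2ccc(Br)cc2)cc(OC)c1OC` gives only a limit of the assay rather than a number, > 80000 nM, which is the limit of > 80000 nM in this assay, at which 1 of the 3 values shown sits.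

Compound 4 `C/C=C/C(=O)N(Cc1ccc(OC)c(O)c1)c1cc(OC)c(OC)c(OC)c1` has not been measured yet. It differs from compound 1 in a single place: prop-1-en-1-yl in place of ethynyl on a carbonyl carbon. Going by the values given here, no pair of measured compounds differs in this way, so the size of the step cannot be read from the data; the three measured compounds differ from one another in several places at once and say nothing about this particular change.

For compound 4 the expected step is a 4.1-fold higher number from compound 1 to compound 4 (0.61 log units; beyond the scatter), a move toward a higher number, of moderate size and probably beyond the scatter of repeated measurements. Compound 4 is therefore expected to give about 700 nM in this assay, with a range from 150 nM to 4000 nM.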

Compound 4, half-maximal inhibitory concentration: 27 nM
Compound 4: middle estimate off by 26-fold (1.41 log units), on the high side; the measured number lies below the stated range.
By their numbers in this assay, from the lowest: compound 4; then compound 1; then compound 2. At a limit, above all of these: compound 3.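

Putting prop-1-en-1-yl in place of ethynyl on a carbonyl carbon gives a 6.3-fold lower number from compound 1 to compound 4 (0.80 log units; beyond the scatter) in this assay, so this position now has a direct comparison, and the group on it clearly affects the reading. The triple bond is not needed for a low number in this pair: a group with a double bond and one more carbon does better than ethynyl, and compound 4 is the lowest of the numbers shown. Compound 2 and compound 3 could not show this, since each differs from compound 1 in several places at once and neither carries a group on this carbonyl carbon.

This one pair changes the bond type and the carbon count together, so it cannot separate the two, and it leaves open how a saturated ethyl group, a longer chain such as butyl, or an amine such as dimethylamino would read at the same position. Nothing in the data shown explains why the number falls with this change.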